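Moving the Methoxy Group on a Weak Inhibitor

The source may report more compounds than this note shows. Statements on the series, on what has been measured and on what is new or still open speak of the compounds shown alone.

compound 1, `COc1ccc(S(=O)(=O)Nc2ccc(-c3nc4ccccc4o3)cc2)cc1`: > 100000 nM
compound 2, `O=S(=O)(Nc1ccc(-c2nc3ccccc3o2)cc1)c1ccc(C(F)(F)F)cc1`: 50000 nM
compound 3, `O=S(=O)(Nc1ccc2oc(-c3ccccc3)nc2c1)c1ccc(F)c(C(F)(F)F)c1`: 69000 nM

All three compounds were tested in an assay on cells for inhibition of HSP60/HSP10 (Homo sapiens), with a stated time of 60 min; a higher number here means a weaker inhibitor, a lower number a stronger inhibitor. Compound 1 sits at the limit of > 100000 nM in this assay, at which 1 of the 3 values shown sits, so for compound 1 only a limit is known, not a number. Compound 2 gives 50000 nM in this assay. Compound 3 gives 69000 nM. Within the data shown here, the only step between two compounds that differ in a single place, an at least 2.0-fold lower number from compound 1 to compound 2 (0.30 log units; that floor lies within the scatter), points toward a lower number, but its floor lies within the usual scatter, so it shows no clear movement.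

Compound 4, `COc1ccccc1S(=O)(=O)Nc1ccc(-c2nc3ccccc3o2)cc1`, has not yet been measured. It differs from compound 1 in one place: 2-methoxyphenyl in place of 4-methoxyphenyl on a sulfonyl sulfur. Among the measured compounds shown here, no measured step moves a group from one position to another on this ring, so none bears directly on the change. For the measured compounds named here, with compound 1 known only as a limit and the one available step no larger than the scatter, compound 4 is expected to stay weak, with an expected step of a number no higher from compound 1 to compound 4 (the limit leaves the size open). Compound 4 is estimated at 100000 nM, within a range from 40000 nM to 300000 nM.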

Compound 4, half-maximal inhibitory concentration: > 100000 nM
Compound 4: only a limit was reported; the forecaster's own chance of this, stated with the estimate: 60%; the middle value sits exactly at the limit.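

No step can be read from compound 1 to compound 4, because each is reported only as a limit: the limit of > 100000 nM in this assay, at which 2 of the 4 values shown sit. The compounds shown leave open how strongly either one inhibits, and whether 2-methoxyphenyl in place of 4-methoxyphenyl changes the number at all.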